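Fluoroalkyl and hydroxyalkyl side chains on a shared core

This account rests on a few compounds, and the source may have more. Where it says the series, first, only, none or still open, it means among the compounds named here.

In an assay on isolated protein for inhibition of Nitric oxide synthase, inducible (Homo sapiens), with a stated time of 30 min (a lower number here means a stronger inhibitor, a higher number a weaker inhibitor), the measured compounds stand as follows:
compound 1 `Cc1cc(N)nc(CC(C)F)c1` gives 220 nM
compound 2 `COC(C)Cc1cc(C)cc(N)n1` gives > 5000 nM, which is a limit of the assay
compound 3 `Cc1cc(N)nc(CC(C)O)c1` gives 1780 nM

Compound 3 holds the highest of the two numbers; its nearest neighbour is compound 1, separated by an 8.1-fold higher number from compound 1 to compound 3 (0.91 log units; beyond the scatter). Compound 4 `Cc1cc(N)nc(CCCCF)c1` differs from compound 3 by 3-fluoropropyl in place of 1-hydroxyethyl on a saturated chain carbon bound to an aromatic carbon. The step that bears on this change runs the other way, an 8.1-fold higher number from compound 1 to compound 3 (0.91 log units; beyond the scatter), so returning fluorine should lower the number. Among the measured compounds shown here, the steps of an at least 22-fold higher number from compound 1 to compound 2 (1.35 log units; beyond the scatter) and an at least 2.8-fold lower number from compound 2 to compound 3 (0.44 log units; beyond the scatter) concern the same position but not a fluoropropyl chain, and the longer chain has no measured counterpart. A lower number in this assay is therefore expected for compound 4, though not the full reversal. Compound 4 is expected to give 400 nM, between 120 nM and 1500 nM. That expectation means a step of a 4.5-fold lower number from compound 3 to compound 4 (0.65 log units; beyond the scatter).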

Compound 4, half-maximal inhibitory concentration: 170 nM
Compound 4: the middle estimate sits 2.4-fold (0.37 log units) above what was measured; low and high end bracket the measured number.
By their numbers in this assay, from the lowest: compounds 4 and 1 (each within the scatter of the next); then compound 3. At a limit, above all of these: compound 2.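

In this assay, the fluorine-bearing chain can be lengthened without a readable change: there is a 1.3-fold lower number from compound 1 to compound 4 (0.11 log units; within the scatter), so 3-fluoropropyl and 1-fluoroethyl cannot be told apart on this saturated chain carbon. The longer fluorinated chain also keeps its advantage over the oxygen-bearing chains, with a 10-fold lower number from compound 3 to compound 4 (1.02 log units; beyond the scatter) and an at least 29-fold lower number from compound 2 to compound 4 (1.46 log units; beyond the scatter). The second of these steps rests on compound 2, whose value is a limit: the limit of > 5000 nM in this assay, at which 1 of the 4 values shown sits.

Going by these compounds, it remains open how a plain propyl chain, a 3-hydroxypropyl chain or an amine at the chain end would compare in this assay. On these data alone, a still longer fluoroalkyl chain also remains open.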